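The compounds below may be only part of what the source reports. "The series", "measured", "known", "first", "only" and "open" are said of these compounds alone.

Measured so far:
compound 1 `COc1cc(Nc2nc3ccccc3nc2S(=O)(=O)c2ccccc2)cc(OC)c1OC` — 29100 nM
compound 2 `COc1ccc(S(=O)(=O)c2nc3ccccc3nc2Nc2cc(OC)c(OC)c(OC)c2)cc1` — 7850 nM

Both compounds share one core and differ only on the aryl ring carried by the sulfonyl group. In a functional assay on PC-3 cells (Homo sapiens) for cytotoxicity, read by MTT assay, with a stated time of 72 h (a lower number here means a stronger inhibitor, a higher number a weaker inhibitor), compound 1 gives 29100 nM, and compound 2 gives 7850 nM. Going by the values given here, the single step measured so far, a 3.7-fold lower number from compound 1 to compound 2 (0.57 log units; beyond the scatter), puts compound 2 at the lowest number of the two, with compound 1 as the only neighbour.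

Compound 3 `COc1cc(Nc2nc3ccccc3nc2S(=O)(=O)c2ccc(Br)cc2)cc(OC)c1OC` is not yet measured. It differs from compound 2 by bromo in place of methoxy on an aromatic carbon, para to a large group. Among the compounds with values here, no measured step covers an exchange of methoxy for bromo; the only step available, a 3.7-fold lower number from compound 1 to compound 2 (0.57 log units; beyond the scatter), concerns the presence of methoxy against hydrogen and shows that this position is sensitive to substitution. Whether bromo recovers the whole gain of the methoxy, part of it, or none is open. The expected step in this assay is therefore a 1.5-fold higher number from compound 2 to compound 3 (0.18 log units; within the scatter), close to no change beyond the scatter and, if anything, toward a somewhat higher number. Compound 3 is estimated at 12000 nM, with a range from 4000 nM to 40000 nM.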

Compound 3, half-maximal inhibitory concentration: 19800 nM
Estimate against measurement, compound 3: 1.7-fold (0.22 log units) below, within the range that was stated.
By their numbers in this assay, from the lowest: compound 2; then compounds 3 and 1 (each within the scatter of the next).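

In this assay, bromo in place of methoxy on the aryl ring of the sulfonyl group gives a 2.5-fold higher number from compound 2 to compound 3 (0.40 log units; beyond the scatter) and so does not keep the gain that methoxy brought at this place. Against hydrogen at the same place, bromo gives a 1.5-fold lower number from compound 1 to compound 3 (0.17 log units; within the scatter), which leaves compound 3 and compound 1 indistinguishable in this assay and shows that a substituent at this place does not by itself lower the number. Of the three groups shown here, only methoxy separates from the other two by a step beyond the scatter, and no measurement on hand bears on the reason for this difference.

From the compounds shown here alone, whether the gain belongs to methoxy alone or extends to other groups at this place, such as a hydroxyl, an ethoxy, a dimethylamino or a fluoro, stays open. Also open is whether the same ordering of methoxy against bromo holds when the trimethoxy-substituted part of the shared core is changed, or outside the single cell assay shown here.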